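Oxazole series: tetrazolylpyridine replacing carboxypyridine

The source may report more compounds than this note shows. Statements on the series, on what has been measured and on what is new or still open speak of the compounds shown alone.

Going by the values given here, compound 2 `O=C(O)c1ccc(-c2cnc(C(=O)CCc3ccc(COc4ccccc4)cc3)o2)nc1` in an assay for inhibition of Fatty-acid amide hydrolase 1 (Rattus norvegicus) (on this read-out higher numbers stand for weaker inhibition and lower numbers for stronger inhibition), gives 4.6 nM, the higher of the two numbers measured so far. Its nearest neighbour is compound 1 `CNC(=O)c1cnc(C(=O)CCc2ccc(COc3ccccc3)cc2)o1`, which in this assay gives 3.6 nM; the step of a 1.3-fold higher number from compound 1 to compound 2 (0.11 log units; within the scatter) is within the scatter, so the two compounds cannot be ordered.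

Compound 3 `O=C(CCc1ccc(COc2ccccc2)cc1)c1ncc(-c2cccc(-c3nnn[nH]3)n2)o1` is not yet measured. It differs from compound 2 at the same position of the shared core that was changed between compound 1 and compound 2: 6-(1H-tetrazol-5-yl)pyridin-2-yl in place of 5-carboxypyridin-2-yl on an aromatic carbon.

Among the compounds with values here, only one measured step bears on this change, a 1.3-fold higher number from compound 1 to compound 2 (0.11 log units; within the scatter), and it is within the scatter. That step swapped a small group for a substituted pyridine at this position without moving the number beyond the scatter, so the position tolerates a substantial change in what is attached. Within the data shown here, the present change keeps the pyridine and alters its substituent and the substituent's position; no measured pair addresses a tetrazole. The expected step in this assay is therefore a 1.1-fold higher number from compound 2 to compound 3 (0.04 log units; within the scatter), none beyond the scatter, with a wide range to cover the untested group. For compound 3 the estimate in this assay is 5 nM, with a range from 1.5 nM to 20 nM.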

Compound 3, inhibition constant: 21 nM
For compound 3 the middle estimate is 4.2-fold (0.62 log units) below the measured one, outside the stated range (above it).
By their numbers in this assay, from the lowest: compounds 1 and 2 (each within the scatter of the next); then compound 3.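

In this assay, this position on the aromatic carbon next to the ring oxygen proves less permissive than the first pair suggested: there is a 4.6-fold higher number from compound 2 to compound 3 (0.66 log units; beyond the scatter), and a 5.8-fold higher number from compound 1 to compound 3 (0.77 log units; beyond the scatter), both modest, while methylcarbamoyl and 5-carboxypyridin-2-yl could not be told apart. Keeping a pyridine on the oxazole-type ring is therefore not enough to hold the number, since compound 2 and compound 3 both carry one and still differ beyond the scatter; what the pyridine bears, or where it bears it, matters in this assay. Nothing available explains the weaker inhibition seen with 6-(1H-tetrazol-5-yl)pyridin-2-yl.

The step from compound 2 to compound 3 changes both the acid-bearing group and its place on the pyridine, so the compounds shown cannot separate the two changes. A 5-(1H-tetrazol-5-yl)pyridin-2-yl group and a 6-carboxypyridin-2-yl group would divide them, showing whether the tetrazole or its placement accounts for the step.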